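The compounds below may be only part of what the source reports. "The series", "measured", "known", "first", "only" and "open" are said of these compounds alone.

Measured in a functional assay on SGC-7901 cells (Homo sapiens) for antiproliferative activity, read by MTT assay, with a stated time of 72 h; on this read-out lower numbers stand for stronger inhibition and higher numbers for weaker inhibition:
Compound 1 `COc1cc(-n2cnc3ccc(-c4cc(F)ccc4F)cc32)cc(OC)c1OC`: 6590 nM
Compound 2 `COc1cc(-n2cnc3ccc(-c4cccc(C)c4C)cc32)cc(OC)c1OC`: 3040 nM

Of these two compounds, compound 2 has the lower number, at 3040 nM, and so shows the stronger inhibition in this assay. The next compound, compound 3 `COc1cc(-n2cnc3ccc(-c4ccc(Cl)cc4Cl)cc32)cc(OC)c1OC`, keeps the shared core but carries 2,4-dichlorophenyl in place of 2,3-dimethylphenyl on an aromatic carbon.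

Among the compounds with values here, only one measured step bears on this change, and it involves the same position: a 2.2-fold lower number from compound 1 to compound 2 (0.34 log units; beyond the scatter). That step is modest, though beyond the scatter. A single step sets no pattern, but it suggests that exchanging this aryl group moves the number only moderately. The closest measured comparison for a halogen-bearing aryl group is compound 1, at 6590 nM, so a modest rise rather than a large shift is expected. The expected change is a 1.5-fold higher number from compound 2 to compound 3 (0.17 log units; within the scatter). For compound 3 the estimated value is 4500 nM, with an expected range from 1800 nM to 11000 nM.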

Compound 3, half-maximal inhibitory concentration: > 10000 nM
Compound 3 ended at the assay's limit (the forecaster's own chance of this, stated with the estimate: 3%); middle value at least 2.2-fold (0.34 log units) away from the limit.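

In this assay compound 3 stands at a limit of the assay and not at a number: the limit of > 10000 nM in this assay, at which 1 of the 3 values shown sits.

Even so, the position proves more sensitive to the choice of aryl group than the earlier pair could show, since the earlier step was only a 2.2-fold lower number from compound 1 to compound 2 (0.34 log units; beyond the scatter), whereas exchanging 2,3-dimethylphenyl for 2,4-dichlorophenyl gives an at least 3.2-fold higher number from compound 2 to compound 3 (0.51 log units; beyond the scatter), and with both steps beyond the scatter, compound 2 shows the strongest inhibition of the three. The comparison between the two halogen-bearing compounds is less firm: the result is an at least 1.5-fold higher number from compound 1 to compound 3 (0.18 log units; that floor lies within the scatter), so their order remains unsettled.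

The compounds shown leave open how much of these steps belongs to the kind of substituent and how much to where it sits on the aryl ring, as the three aryl groups differ in both. They also leave open how an aryl group carrying an amine or a carboxylic acid would read at this position on the shared core.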